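The source may hold more compounds than are shown below. What is called first, only, known or untested is meant among the compounds shown, and "the series" means these compounds.

Measured in a functional assay on A549 cells (Homo sapiens) for antiproliferative activity, read by MTT assay, with a stated time of 48 h; on this read-out lower numbers stand for stronger inhibition and higher numbers for weaker inhibition:
- Compound 1 `COc1ccc(-c2nc3cccc(-c4cc(OC)c(OC)c(OC)c4)c3o2)cc1`: 2200 nM
- Compound 2 `COc1cc(-c2cccc3nc(-c4ccc(C)cc4)oc23)cc(OC)c1OC`: 680 nM

Among the compounds with values here, compound 2 holds the lower of the two numbers so far, at 680 nM. Compound 3 `COc1cc(-c2cccc3nc(-c4ccc5cc[nH]c5c4)oc23)cc(OC)c1OC` keeps the shared core but carries 1H-indol-6-yl in place of 4-methylphenyl, on an aromatic carbon of a five-membered aromatic ring with 1 nitrogen and 1 oxygen (1H-indol-6-yl in place of 4-methylphenyl on an aromatic carbon). Within the data shown here, only one measured step bears on this: a 3.2-fold lower number from compound 1 to compound 2 (0.51 log units; beyond the scatter), a modest change beyond the scatter, made within the group that now leaves. Among the measured compounds shown here, no measured compound carries 1H-indol-6-yl, so the direction remains uncertain. On the strength of that single step, a change of similar modest size is expected, leaning slightly towards a lower number in this assay. The expected change is a 1.7-fold lower number from compound 2 to compound 3 (0.23 log units; within the scatter). Compound 3 is estimated at 400 nM, with an expected range of 80 nM to 2000 nM.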

Compound 3, half-maximal inhibitory concentration: 55 nM
Compound 3: the middle estimate sits 7.3-fold (0.86 log units) above what was measured; the measured number lies below the stated range.
By their numbers in this assay, from the lowest: compound 3; then compound 2; then compound 1.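

In this assay, this place on the five-membered aromatic ring with 1 nitrogen and 1 oxygen proves far more responsive than a 3.2-fold lower number from compound 1 to compound 2 (0.51 log units; beyond the scatter) suggested, since that modest step came from changing only a substituent on the phenyl group. Replacing the whole phenyl group with 1H-indol-6-yl gives a 12-fold lower number from compound 2 to compound 3 (1.09 log units; beyond the scatter) and, against the methoxy compound, a 40-fold lower number from compound 1 to compound 3 (1.60 log units; beyond the scatter), both large steps. No measurement at hand accounts for the size of this change.

The entering group brings a five-membered aromatic ring and a hydrogen-bond donor together, and the compounds shown do not separate the two. A phenyl group carrying an amine, or an indole with a methyl group on its nitrogen, would bear on that question.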